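Compound 1 to compound 4: replacing the 4-bromo-3-nitrophenyl group

The source may hold more compounds than are shown below. What is called first, only, known or untested is meant among the compounds shown, and "the series" means these compounds.

Compound 1 (`O=C(O)c1ccc(C(=O)/C(=C\c2ccc(Br)c([N+](=O)[O-])c2)SCc2ccc(Cl)cc2)cc1`) gives < 1000 nM in a functional assay on DU-145 cells (Homo sapiens) for inhibition, read by trypan blue exclusion, with a stated time of 96 h (on this read-out higher numbers stand for weaker inhibition of growth and lower numbers for stronger inhibition of growth), as a limit, not a number. Two halogen variants give full numbers: compound 2 (`O=C(O)c1ccc(C(=O)/C(=C\c2ccc(Br)c([N+](=O)[O-])c2)SCc2ccc(Cl)cc2Cl)cc1`) reads 1000 nM and compound 3 (`O=C(O)c1ccc(C(=O)/C(=C\c2ccc(Br)c([N+](=O)[O-])c2)SCc2ccc(F)cc2)cc1`) reads 1000 nM in the same read-out.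

Compound 4 (`CSc1ccc(/C=C(/SCc2ccc(Cl)cc2)C(=O)c2ccc(C(=O)O)cc2)cc1`) puts 4-(methylsulfanyl)phenyl in place of 4-bromo-3-nitrophenyl on a double-bonded chain carbon bound to a double-bonded chain carbon.

The measured steps bear on this change only indirectly. All of them alter the phenyl on the saturated chain carbon bound to a sulfur, and none touches the 4-bromo-3-nitrophenyl. Two of them are a number no lower from compound 1 to compound 2 (the limit leaves the size open) and a number no lower from compound 1 to compound 3 (the limit leaves the size open) with their sizes left open. The third is no change at the digits printed from compound 2 to compound 3 (within the scatter) and stays within the scatter.

No direct measure of the new group exists, so the expectation rests on compound 2 at 1000 nM as the nearest full number. A modest rise in this assay is expected, meaning weaker inhibition of growth, and the estimate is an at least 2.0-fold higher number from compound 1 to compound 4 (0.30 log units; that floor lies within the scatter) with considerable uncertainty. Compound 4 is expected at 2000 nM within an estimated range from 500 nM to 8000 nM in this read-out.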

Compound 4, concentration for 50% growth inhibition: > 100000 nM
Compound 4 ended at the assay's limit; the forecaster's own chance of this, stated with the estimate: 25%; at least 50-fold (1.69 log units) between middle value and limit.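

In this assay, 4-(methylsulfanyl)phenyl in place of 4-bromo-3-nitrophenyl gives an at least 100-fold higher number from compound 1 to compound 4 (2.00 log units; beyond the scatter), which shows that the group at this place, on a double-bonded chain carbon bound to a double-bonded chain carbon, can take growth inhibition out of the range of the assay. The earlier steps changed only the phenyl on the saturated chain carbon bound to a sulfur: the step between compound 2 and compound 3 stayed within the scatter, and the two steps from compound 1 cannot be read, so this is the only step in the compounds shown with a readable size beyond the scatter. Both ends of this step are limits of the assay and not numbers, so its full size stays open: the limit of > 100000 nM in this assay, at which 1 of the 4 values shown sits.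

The swap removes the bromine and the nitro group and brings in the methylsulfanyl group in a single change, so the compounds shown cannot assign the loss to any one of the three. An unsubstituted phenyl, or a phenyl carrying only the bromine or only the nitro group, would separate these parts at this place.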